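Swapping the Chlorophenyl Group: Compound 2 to Compound 3

The source may hold more compounds than are shown below. What is called first, only, known or untested is meant among the compounds shown, and "the series" means these compounds.

Of the compounds shown here, two have been measured in a functional assay on MCF7 cells (Homo sapiens) for inhibition, read by MTT assay, with a stated time of 48 h, tested at 10 uM; on this read-out lower numbers stand for less inhibition of growth and higher numbers for more inhibition of growth at the one concentration tested. Compound 1 `Cc1cc(=O)c2c(O)cc(OCc3ccccc3)c([C@H]3CCN(C)C[C@H]3O)c2o1` gives 1% there. Compound 2 `Cc1oc2c([C@H]3CCN(C)C[C@H]3O)c(O)cc(O)c2c(=O)c1C(O)c1ccc(Cl)cc1` gives 6%, the higher of the two numbers, although its gap to compound 1 lies within the scatter. Compound 3 `Cc1oc2c([C@H]3CCN(C)C[C@H]3O)c(O)cc(O)c2c(=O)c1C(O)c1cccc(Cl)c1Cl` differs from compound 2 in one place: 2,3-dichlorophenyl in place of 4-chlorophenyl on a saturated chain carbon bound to an aromatic carbon and an oxygen on a saturated carbon. For the measured compounds named here, no step between measured compounds is known, so nothing points to a step beyond the scatter; the expected step of a number 2 percentage points higher from compound 2 to compound 3 (within the scatter) is small, in no clear direction. Compound 3 is expected to give about 8% in this assay, within a range from -5% to 25%.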

Compound 3, percent growth inhibition at one concentration: 7%
For compound 3 the middle estimate is 1 percentage points above the measured one, within the range that was stated.
By their numbers in this assay, from the lowest: compounds 1, 2 and 3 (each within the scatter of the next).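

In this assay, 2,3-dichlorophenyl in place of 4-chlorophenyl gives a number 1 percentage points higher from compound 2 to compound 3 (within the scatter). For the compounds shown here, this is the first change in one place that can be read, and at this position it shows no clear effect of swapping one chlorophenyl group for the other. Nothing at hand offers an explanation for this result.

Going by these compounds, it remains open whether an amine or a carboxylic acid in place of the chlorophenyl group would give a step beyond the scatter. Whether this position matters at all for growth inhibition also stays unsettled.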